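This account rests on a few compounds, and the source may have more. Where it says the series, first, only, none or still open, it means among the compounds named here.

In a functional assay on HEL cells (Homo sapiens) (a higher number here means that more compound is tolerated, a lower number that less compound is tolerated), compound 3 `Cc1cn([C@@H]2O[C@H](CO[Si](C)(C)C(C)(C)C)[C@@]3(OS(=O)(=O)C=C3NCCC(=O)OCc3ccccc3)[C@H]2O[Si](C)(C)C(C)(C)C)c(=O)n(C)c1=O` gives 200000 nM. Compound 1 `Cc1cn([C@@H]2O[C@H](CO[Si](C)(C)C(C)(C)C)[C@@]3(OS(=O)(=O)C=C3NCC(=O)O)[C@H]2O[Si](C)(C)C(C)(C)C)c(=O)n(C)c1=O` gives 136000 nM and compound 2 `Cc1cn([C@@H]2O[C@H](CO[Si](C)(C)C(C)(C)C)[C@@]3(OS(=O)(=O)C=C3NCC(=O)C(=O)O)[C@H]2O[Si](C)(C)C(C)(C)C)c(=O)n(C)c1=O` gives 146000 nM, so all three lie within the scatter of one another. Compound 4 `COC(=O)CCNC1=CS(=O)(=O)O[C@@]12[C@@H](CO[Si](C)(C)C(C)(C)C)O[C@@H](n1cc(C)c(=O)n(C)c1=O)[C@@H]2O[Si](C)(C)C(C)(C)C` differs from compound 3 at the end of the side chain: hydrogen in place of phenyl on a saturated chain carbon bound to an oxygen next to a carbonyl group, which turns benzyloxycarbonyl into methoxycarbonyl. Among the measured compounds shown here, no measured step makes this exact change, but three steps alter the same side chain: a 1.1-fold higher number from compound 1 to compound 2 (0.03 log units; within the scatter), a 1.5-fold higher number from compound 1 to compound 3 (0.17 log units; within the scatter) and a 1.4-fold higher number from compound 2 to compound 3 (0.14 log units; within the scatter). None leaves the scatter, so no step beyond the scatter is expected in this assay, in either direction. The expected step is a 1.2-fold lower number from compound 3 to compound 4 (0.07 log units; within the scatter). Compound 4 is estimated at 170000 nM, with an expected range from 100000 nM to 260000 nM.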

Compound 4, half-maximal cytotoxic concentration: 94000 nM
Beside the measured number, compound 4's estimate is 1.8-fold (0.26 log units) above it; measured number below the stated range.
By their numbers in this assay, from the lowest: compounds 4, 1, 2 and 3 (each within the scatter of the next, the first and the last beyond it).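

In this assay the change from benzyloxycarbonyl to methoxycarbonyl gives a 2.1-fold lower number from compound 3 to compound 4 (0.33 log units; beyond the scatter) as a modest step, the first on this side chain to leave the scatter. The same compound stays within the scatter of the two shorter-chain acids, with a 1.6-fold lower number from compound 2 to compound 4 (0.19 log units; within the scatter) and a 1.4-fold lower number from compound 1 to compound 4 (0.16 log units; within the scatter) as the printed steps, so losing the phenyl has only a small effect on this number. Nothing available explains this step. Going by these compounds, what an ethyl ester or an amine at the end of this chain would do remains open. So does whether a longer chain would shift the number further.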